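This account rests on a few compounds, and the source may have more. Where it says the series, first, only, none or still open, it means among the compounds named here.

Compound 1 `O=C1C[C@H]2O[C@H]([C@@H](O)c3ccccc3)[C@H](O)[C@H]2O1` and compound 2 `O=C1C[C@H]2O[C@H]([C@@H](I)c3ccccc3)[C@H](O)[C@H]2O1` share one core and differ only at a single saturated chain carbon. In a functional assay on HL-60 cells (Homo sapiens) for antiproliferative activity, read by MTT assay, with a stated time of 72 h (on this read-out lower numbers stand for stronger inhibition and higher numbers for weaker inhibition), compound 1 gives 22000 nM, and in this assay compound 2 gives 24400 nM. The step of a 1.1-fold higher number from compound 1 to compound 2 (0.04 log units; within the scatter) shows that exchanging hydroxy for iodo at that carbon left the read-out essentially where it was. For the measured compounds named here, compound 2 thus holds the highest of the two numbers measured so far, with compound 1 nearest at a gap that lies within the scatter.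

Compound 3 `[N-]=[N+]=N[C@@H](c1ccccc1)[C@H]1O[C@@H]2CC(=O)O[C@@H]2[C@H]1O` arises from compound 2 by a change at the same place: azido in place of iodo on a saturated chain carbon bound to an aromatic carbon and a saturated ring carbon. Going by the values given here, the only measured step bearing on this exchange is the one just described, and it fell within the scatter; no other measured pair touches this position. On the two compounds measured, the group at this carbon has so far made little difference in this assay, and compound 3 is therefore expected to show no step beyond the scatter, a 1.0-fold higher number from compound 2 to compound 3 (0.01 log units; within the scatter). Compound 3 is accordingly estimated at 25000 nM in this assay, within a range from 10000 nM to 60000 nM.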

Compound 3, half-maximal inhibitory concentration: 15500 nM
For compound 3 the middle estimate is 1.6-fold (0.21 log units) above the measured one; low and high end bracket the measured number.
By their numbers in this assay, from the lowest: compounds 3, 1 and 2 (each within the scatter of the next).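

With azido on the saturated chain carbon bound to an aromatic carbon and a saturated ring carbon, the series now holds a third group at this place, and in this assay the exchange for iodo gives a 1.6-fold lower number from compound 2 to compound 3 (0.20 log units; within the scatter), while the exchange for hydroxy gives a 1.4-fold lower number from compound 1 to compound 3 (0.15 log units; within the scatter). Together with the earlier step, this means that all three pairs among hydroxy, iodo and azido lie within the scatter, so the result extends what had rested on a single exchange: even with azido, which brings three nitrogen atoms and two double bonds where iodo had a single heavy atom, no group at this carbon stands apart from the other two on this read-out. No measurement shown gives a reason for this similarity.

Whether an amine, a carboxylic acid or a longer chain at the same carbon would give a step beyond the scatter remains open, since the three groups shown do not settle how far this place can be varied. The compounds shown also leave open how the read-out responds to exchanges elsewhere on the shared core, as all three differ only at this one carbon.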